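Aryl replacements on the benzylic carbinol side chain

This account rests on a few compounds, and the source may have more. Where it says the series, first, only, none or still open, it means among the compounds named here.

The series shares one core: a lactam-bearing acid chain with a trans-olefin leading to a secondary alcohol, then a benzyl group carrying a variable substituent. Compound 1 is `O=C(O)CCCSCCN1C(=O)CC[C@@H]1/C=C/[C@@H](O)Cc1cccc(N2Cc3ccccc3C2)c1`. In an assay on CHO cells for displacement of a labelled ligand from prostaglandin E2 receptor EP2 subtype (Mus musculus), read by scintillation counting, with a stated time of 60 min (on this read-out lower numbers stand for stronger inhibition and higher numbers for weaker inhibition), compound 1 gives only a limit, > 10000 nM, so it sits at the weak end of the numbers seen here, as marked by the limit of > 10000 nM in this assay, at which 1 of the 3 values shown sits.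

Compound 2 is `O=C(O)CCCSCCN1C(=O)CC[C@@H]1/C=C/[C@@H](O)Cc1cccc(-c2ccc3[nH]ccc3c2)c1` and in this assay compound 2 gives 3500 nM. Compound 3 is `O=C(O)CCCSCCN1C(=O)CC[C@@H]1/C=C/[C@@H](O)Cc1cccc(-c2nc3ccccc3s2)c1` and in this assay compound 3 gives 720 nM. The two steps from compound 1 are an at least 2.8-fold lower number from compound 1 to compound 2 (0.45 log units; beyond the scatter) and an at least 13-fold lower number from compound 1 to compound 3 (1.14 log units; beyond the scatter); between the two aromatic groups the step is a 4.9-fold lower number from compound 2 to compound 3 (0.69 log units; beyond the scatter).

Compound 4 is `O=C(O)CCCSCCN1C(=O)CC[C@@H]1/C=C/[C@@H](O)Cc1cccc(OCc2ccncc2)c1`, not yet measured in this assay. It differs from compound 1 by a group of 8 heavy atoms (6 carbon, 1 nitrogen, 1 oxygen; one six-membered aromatic ring with 1 hetero atom) in place of a group of 9 heavy atoms (8 carbon, 1 nitrogen; one five-membered non-aromatic ring with 1 hetero atom, one six-membered aromatic ring of carbon only), on an aromatic carbon. Both measured steps from compound 1 swapped the non-aromatic bicycle for a directly attached aromatic bicycle; neither introduced an ether-linked single ring, so they bear only loosely on this change. The expectation for compound 4 is a number near the limit of compound 1, with at most a modest move downward, that is an at least 1.2-fold lower number from compound 1 to compound 4 (0.09 log units; that floor lies within the scatter). Compound 4 is therefore estimated at 8000 nM, within 2000 nM to 30000 nM.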

Compound 4, inhibition constant: > 10000 nM
Compound 4: no number, only a limit (the forecaster's own chance of this, stated with the estimate: 40%); at least 1.2-fold (0.09 log units) between middle value and limit.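

The value for compound 4 is a limit of the assay and not a number, and it places the (pyridin-4-yl)methoxy group at the weak end of the series alongside the group of compound 1: the limit of > 10000 nM in this assay, at which 2 of the 4 values shown sit.

In this assay, this ether-linked single ring falls behind both directly attached aromatic bicycles, with an at least 2.8-fold higher number from compound 2 to compound 4 (0.45 log units; beyond the scatter) and an at least 13-fold higher number from compound 3 to compound 4 (1.14 log units; beyond the scatter), so among the four compounds only those two bicycles, in compound 2 and compound 3, give a number rather than a limit. The step between compound 1 and compound 4 cannot be read, as both ends are limits, and the two groups cannot be ordered against each other.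

Compound 4 changes the ring and the linkage together, so the shown compounds leave open whether the loss follows the oxygen and methylene link, the single ring or the ring nitrogen. A directly attached pyridin-4-yl group and a benzyloxy group would separate these parts, and a directly attached phenyl group would test whether any single aromatic ring at this place gives a readable number.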